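Sigma-2 binding: adding a third methoxy to compound 2

The compounds below may be only part of what the source reports. "The series", "measured", "known", "first", "only" and "open" are said of these compounds alone.

Measured compounds:
Compound 1, `COc1cc2c(c(OC)c1OC)CCN(CCC(=O)c1c(C)c(OC)c(OC)c(OC)c1OC)C2`: 11500 nM
Compound 2, `COc1cc2c(cc1OC)CN(CCCC(=O)c1c(C)c(OC)c(OC)c(OC)c1OC)CC2`: 5.1 nM

In an assay on membranes from liver for displacement of a labelled ligand from Sigma intracellular receptor 2 (Rattus norvegicus), read by scintillation counting, with a stated time of 120 min (on this read-out higher numbers stand for weaker inhibition and lower numbers for stronger inhibition), compound 2 gives 5.1 nM, the lowest of the two numbers shown. Its nearest neighbour is compound 1, which in this assay gives 11500 nM, a gap far beyond the scatter. Among the compounds with values here, the two differ in more than one place, so no single step links them, and their values can only be read side by side.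

Compound 3, `COc1cc2c(c(OC)c1OC)CCN(CCCC(=O)c1c(C)c(OC)c(OC)c(OC)c1OC)C2`, has not yet been measured. It differs from compound 2 by one change: methoxy in place of hydrogen on an aromatic carbon, a methoxy in place of hydrogen on an aromatic carbon. Since the very weak number of compound 1 carries the same extra methoxy together with a shorter chain, the risk of a loss is real. The step from compound 2 to compound 3 is therefore expected to be a weakening of about a 12-fold higher number from compound 2 to compound 3 (1.07 log units; beyond the scatter). Compound 3 is estimated at 60 nM in this assay, with a range from 6 nM to 1500 nM.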

Compound 3, inhibition constant: 41.8 nM
Beside the measured number, compound 3's estimate is 1.4-fold (0.16 log units) above it, and the stated range covers the measured number.
By their numbers in this assay, from the lowest: compound 2; then compound 3; then compound 1.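

Methoxy in place of hydrogen on this aromatic carbon, ortho to a methoxy group, weakens binding in this assay but leaves it measurable at a low level: the change gives an 8.2-fold higher number from compound 2 to compound 3 (0.91 log units; beyond the scatter) and is beyond the usual scatter. Like compound 1, compound 3 carries the same extra methoxy and gives 41.8 nM, whereas compound 1 gives 11500 nM and has the shorter chain. The extra methoxy alone therefore does not bring the number anywhere near that of compound 1.

Nothing shown here explains why the methoxy raises the number. On these data alone, whether a hydroxyl, an ethoxy or a fluorine atom on this aromatic carbon would give a number closer to that of compound 2 stays open, as does what a longer chain would do in compound 3.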